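Cytotoxicity in the quinoline–pyrimidine diamine series: chloro to methyl

The compounds below may be only part of what the source reports. "The series", "measured", "known", "first", "only" and "open" are said of these compounds alone.

Measured compounds:
compound 1, `Clc1ccc2c(NCCNc3nccc(Nc4ccccc4)n3)ccnc2c1`: "not active" (no number reported)
compound 2, `Fc1ccc(Nc2ccnc(NCCNc3ccnc4cc(Cl)ccc34)n2)cc1`: "not active" (no number reported)
compound 3, `Clc1ccc(Nc2ccnc(NCCNc3ccnc4cc(Cl)ccc34)n2)cc1`: 15800 nM

In an ADME assay on Vero cells (Chlorocebus sabaeus) for cytotoxicity, read by neutral red uptake, with a stated time of 72 h (a higher number here means a weaker inhibitor, a lower number a stronger inhibitor), compound 3 gives 15800 nM, the only numerical result obtained so far in this set. Compound 1 returns "not active" (no number reported) in this assay, without a number. Compound 2 likewise returns "not active" (no number reported) in this assay. Among the compounds with values here, compound 3 therefore stands alone as the one entry with a quantified read-out, and no pair of measured compounds differs in a single place, so no measured step is available.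

Compound 4, `Cc1ccc(Nc2ccnc(NCCNc3ccnc4cc(Cl)ccc34)n2)cc1`, is the next entry to be measured in this assay. Its difference from compound 3 is methyl in place of chloro on an aromatic carbon.

Within the data shown here, with no measured step to lean on, the expectation rests on the position of compound 3 alone, whose value 15800 nM lies far from the potent end of the scale. The step from compound 3 to compound 4 is expected to be small, a 1.3-fold higher number from compound 3 to compound 4 (0.10 log units; within the scatter), close to the usual scatter and, if anything, toward a weaker inhibitor. Compound 4 is accordingly estimated at 20000 nM in this assay, with a range from 8000 nM to 50000 nM.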

Compound 4, half-maximal inhibitory concentration: 13600 nM
Beside the measured number, compound 4's estimate is 1.5-fold (0.17 log units) above it, and the stated range covers the measured number.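

Within the data shown here, the first step that can be read in this assay is a 1.2-fold lower number from compound 3 to compound 4 (0.07 log units; within the scatter) and it shows that methyl in place of chloro on an aromatic carbon, para to a large group, leaves the read-out within the scatter. At this position of the 4-chlorophenyl group, the two substituents of one heavy atom each cannot be told apart in this assay, and compound 4 joins compound 3 as a second entry with a number, whereas compound 1 and compound 2 return none. No measurement at hand bears on the reason for this outcome, so no cause can be assigned to it.

The compounds shown leave open whether a group of another kind at the same place, such as an amine, a carboxylic acid or a methoxy group, would keep the read-out where compound 3 and compound 4 stand. They also leave open how the read-out would respond to a longer chain in place of the link within the shared core, since every compound shown carries the same link.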